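The compounds below may be only part of what the source reports. "The series", "measured", "known", "first", "only" and "open" are said of these compounds alone.

Working notes on the series

Compound 1 `COc1ncccc1OC[C@@H]1CCCN1` and compound 2 `COc1ncccc1OC[C@@H]1CCCN1C` share one core; compound 3 `COc1ccccc1OC[C@@H]1CCCN1` and compound 4 `COc1ccccc1OC[C@@H]1CCCN1C` share another. The difference between the two cores is not broken down here.

In an assay on cell membranes for displacement of a labelled ligand from Neuronal acetylcholine receptor; alpha4/beta2 (Rattus norvegicus), read by scintillation counting (a higher number here means a weaker inhibitor, a lower number a stronger inhibitor), compound 1 gives 8960 nM. Compound 2 gives 7280 nM in this assay. The change from compound 1 to compound 2 is methyl in place of hydrogen on an amine nitrogen in a ring, and the step it made is a 1.2-fold lower number from compound 1 to compound 2 (0.09 log units; within the scatter).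

Compound 3 gives 53500 nM in this assay, the highest number of the three measured, with compound 1 as the nearest and compound 2 the furthest, both gaps beyond the scatter.

The change from compound 3 to compound 4 is methyl in place of hydrogen on an amine nitrogen in a ring. The place is described in the same words as for the step from compound 1 to compound 2, so this is the same change made on the other core. On that single precedent, which stayed within the scatter, the step is expected to be a 1.2-fold lower number from compound 3 to compound 4 (0.08 log units; within the scatter), because the earlier one was a 1.2-fold lower number from compound 1 to compound 2 (0.09 log units; within the scatter). Compound 4 is therefore expected to give about 45000 nM in this assay, within a range from 20000 nM to 110000 nM.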

Compound 4, inhibition constant: 9400 nM
Estimate against measurement, compound 4: 4.8-fold (0.68 log units) above; the measured number lies below the stated range.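

In this assay, methyl in place of hydrogen on an amine nitrogen in a ring gave a 5.7-fold lower number from compound 3 to compound 4 (0.76 log units; beyond the scatter), so the size of the step did not carry over from one core to the other: the same change on two cores in this assay, a 1.2-fold lower number (0.09 log units; within the scatter) from compound 1 to compound 2 and a 5.7-fold lower number (0.76 log units; beyond the scatter) from compound 3 to compound 4, 4.6-fold (0.67 log units) apart, beyond the scatter of two such steps

On the core of compound 1 the change stays within the scatter, while on the core of compound 3 it goes beyond it, so a step read on one of these cores is a poor guide to the same step on the other. This rests on a single pair of steps, and it does not show what in the two cores sets them apart, nor how the change would behave on any further core.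

Open, on these data alone, is whether ethyl or a longer chain on the same amine nitrogen would follow the step seen on either core. Also open, as far as these compounds go, is whether a hydroxyl in place of the methoxy group would leave the methyl step closer to that of compound 3 to compound 4 or to that of compound 1 to compound 2.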